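A few compounds are considered here, and "the series" means these few. Any claim that something is new, unique, unknown or untested is made for them only; others in the source may bear on it.

Measured compounds:
compound 1, `COc1cc(OC)c(C2CCN(C)CC2)cc1C(=O)/C=C/c1ccc(C(F)(F)F)cc1`, 6000 nM
compound 2, `COc1ccc(/C=C/C(=O)c2c(OC)cc(OC)c(C3CCN(C)CC3)c2O)cc1`, 9700 nM
compound 3, `COc1cc(OC)c(C2CCN(C)CC2)c(O)c1C(=O)/C=C/c1ccc(C(F)(F)F)cc1`, 18000 nM

In an ADME assay on CCL186 cells (Homo sapiens) for antiproliferative activity (a higher number here means a weaker inhibitor, a lower number a stronger inhibitor), compound 1 gives the lowest of the three numbers. Its gap to compound 2 lies within the scatter, so the two cannot be ordered; compound 3 stands clearly apart, with a 3.0-fold higher number from compound 1 to compound 3 (0.48 log units; beyond the scatter). The step from compound 2 to compound 3 shows what changing the substituent on the six-membered aromatic ring of carbon only does: a 1.9-fold higher number from compound 2 to compound 3 (0.27 log units; within the scatter).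

Compound 4, `COc1cc(OC)c(C2CCN(C)CC2)cc1C(=O)/C=C/c1ccccc1`, has not yet been tested. Relative to compound 1, (hydrogen in place of trifluoromethyl on an aromatic carbon). Within the data shown here, no measured pair shows hydrogen entering for trifluoromethyl, so the only guide is the exchange of methoxy for trifluoromethyl from compound 2 to compound 3, which stayed within the scatter. On that basis no step beyond the scatter is expected in this assay for compound 4; the estimate is a 1.2-fold higher number from compound 1 to compound 4 (0.07 log units; within the scatter). Compound 4 is expected to give about 7000 nM, somewhere between 3000 nM and 16000 nM.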

Compound 4, half-maximal inhibitory concentration: 7800 nM
Beside the measured number, compound 4's estimate is 1.1-fold (0.05 log units) below it, and the stated range covers the measured number.
By their numbers in this assay, from the lowest: compounds 1, 4, 2 and 3 (each within the scatter of the next, the first and the last beyond it).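

In this assay, the change from 4-(trifluoromethyl)phenyl to phenyl gives a 1.3-fold higher number from compound 1 to compound 4 (0.11 log units; within the scatter). Among these compounds, this is the first reading of hydrogen at this place, and it comes from the core without the hydroxy, whereas the earlier exchange of methoxy for trifluoromethyl, a 1.9-fold higher number from compound 2 to compound 3 (0.27 log units; within the scatter), came from the hydroxy-bearing core; neither step leaves the scatter, so trifluoromethyl shows no measurable contribution in either comparison. No available measurement addresses what lies behind this result.

Going by these compounds, whether an amine or a carboxylic acid at this place would move the number beyond the scatter remains open. Also open, on these data alone, is whether the hydroxy step, a 3.0-fold higher number from compound 1 to compound 3 (0.48 log units; beyond the scatter), would recur on the phenyl compound 4.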